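The source may report more compounds than this note shows. Statements on the series, on what has been measured and on what is new or still open speak of the compounds shown alone.

Series notes. In an assay on isolated protein for inhibition of cathepsin S (Homo sapiens), with a stated time of 30 min (on this read-out higher numbers stand for weaker inhibition and lower numbers for stronger inhibition), compound 1 `N#Cc1nc(Nc2ccc(C(F)(F)F)cc2)nc(NC2CCCCC2)n1` gives 102 nM. Compound 3 `Cc1cccc(CNc2nc(C#N)nc(N3CCNCC3)n2)c1` gives 17 nM in this assay. In this assay compound 2 `N#Cc1ccc(Nc2nc(C#N)nc(N3CCNCC3)n2)cc1` has no result reported, so its place among these values is open. Compound 4 `N#Cc1nc(Nc2ccc([N+](=O)[O-])cc2)nc(N2CCNCC2)n1` is not yet measured. The change from compound 2 to compound 4 is nitro in place of cyano on an aromatic carbon. Going by the values given here, no step between two measured compounds is available as a guide, so the step from compound 2 to compound 4 in this assay is expected to be modest, with no clear direction beyond the scatter. Because compound 1 gives 102 nM and compound 3 gives 17 nM, compound 4 is expected to give about 40 nM in this assay, within a range from 8 nM to 200 nM.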

Compound 4, half-maximal inhibitory concentration: 23 nM
The estimate for compound 4 lay 1.7-fold (0.24 log units) above the measured number, within the range that was stated.
By their numbers in this assay, from the lowest: compounds 3 and 4 (each within the scatter of the next); then compound 1.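

In this assay, going by these compounds alone, compound 2 has no single number, so no step to compound 4 can be read. The compounds shown leave open what nitro in place of cyano does to this read-out, and no evidence bears on the result.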